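Amide variation on a shared naphthyl hexafluoro-carbinol core

This account rests on a few compounds, and the source may have more. Where it says the series, first, only, none or still open, it means among the compounds named here.

Measured so far:
compound 1, `O=C(Nc1c(C(O)(C(F)(F)F)C(F)(F)F)ccc2ccccc12)c1cccc([N+](=O)[O-])c1`, 117 nM in an assay on LtK cells with ATP-sensitive inward rectifier potassium channel 11 (Homo sapiens) as the target; on this read-out higher numbers stand for an effect only at larger amounts of compound and lower numbers for an effect already at smaller amounts
compound 2, `COc1ccc(C(=O)Nc2c(C(O)(C(F)(F)F)C(F)(F)F)ccc3ccccc23)cc1`, 417 nM in this assay

For the measured compounds named here, compound 2 stands at the highest of the two numbers seen so far; its nearest neighbour is compound 1, and the one measured step is a 3.6-fold higher number from compound 1 to compound 2 (0.55 log units; beyond the scatter), which changes only the aryl group on the carbonyl carbon.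

Compound 3, `O=C(Nc1c(C(O)(C(F)(F)F)C(F)(F)F)ccc2ccccc12)c1ccco1`, is not yet measured. Its difference from compound 2 is furan-2-yl in place of 4-methoxyphenyl on a carbonyl carbon. Going by the values given here, the change sits at the same position as the one measured step, so that step is the only guide. It shows that exchanging the aryl group on the carbonyl carbon moves the number by a modest amount beyond the scatter, but it gives no direction for a furan-2-yl group, which is a smaller five-membered ring with one hetero atom rather than a substituted six-membered ring of carbon only. On that basis a step of similar size in either direction is possible, and the best expectation for compound 3 in this assay is a 1.4-fold lower number from compound 2 to compound 3 (0.14 log units; within the scatter). Compound 3 is therefore estimated at 300 nM, with a range of 90 nM to 1000 nM.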

Compound 3, half-maximal effective concentration: 9 nM
Compound 3: middle estimate off by 33-fold (1.52 log units), on the high side; the measured number lies below the stated range.
By their numbers in this assay, from the lowest: compound 3; then compound 1; then compound 2.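

On the carbonyl carbon, the exchange of the acyl aryl group can move the number in this assay much further than the first step indicated: a 46-fold lower number from compound 2 to compound 3 (1.67 log units; beyond the scatter) and a 13-fold lower number from compound 1 to compound 3 (1.11 log units; beyond the scatter) are both larger than a 3.6-fold higher number from compound 1 to compound 2 (0.55 log units; beyond the scatter) between the two substituted phenyl groups. Compound 3 has the lowest number of the three whichever phenyl group furan-2-yl is set against, so in these compounds the five-membered aromatic ring with one hetero atom outperforms both six-membered rings of carbon only, although the comparison with 4-methoxyphenyl also changes the count from 8 heavy atoms to 5, and ring size, hetero atom and substituent all change together in these steps. Nothing measured here bears on why the number falls so far, so the result remains an observation about this position.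

Still open, from the compounds shown here alone, is whether the low number belongs to furan-2-yl itself or extends to other small rings on the carbonyl carbon, such as thiophen-2-yl, furan-3-yl or the saturated tetrahydrofuran-2-yl. An unsubstituted phenyl group would show how much of the gap comes from the substituents on the six-membered rings rather than from the ring itself.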